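Series notes: three limits measured, one open analogue

The source may report more compounds than this note shows. Statements on the series, on what has been measured and on what is new or still open speak of the compounds shown alone.

Values in a functional assay on MCF7 cells (Homo sapiens) for cytotoxicity, read by sulforhodamine B assay, with a stated time of 48 h; a higher number here means that more compound is tolerated, a lower number that less compound is tolerated:
Compound 1 `ClCc1ccccc1Cn1cnc2c(Cl)nc(Cl)nc21` gives > 100000 nM, a limit.
Compound 2 `ClCc1ccccc1Cn1cnc2ncnc(Cl)c21` gives > 100000 nM, a limit.
Compound 3 `ClCc1ccc(Cn2cnc3c(Cl)nc(Cl)nc32)cc1` gives > 100000 nM, a limit.

Compound 1 stands where every value in the series sits, at the limit of > 100000 nM in this assay, at which 3 of the 3 values shown sit. None of the three compounds yields a number, and no order among compounds 1, 2 and 3 can be read from this. Compound 4 `Nc1nc(Cl)c2ncn(Cc3ccccc3CCl)c2n1` differs from compound 1 by amino in place of chloro on an aromatic carbon. Among the compounds with values here, no measured step between two compounds differing in one place exists here, so the series gives no size for such a change; the expected step from compound 1 to compound 4 in this assay is a number no higher from compound 1 to compound 4 (the limit leaves the size open), none beyond the scatter. Compound 4 is accordingly estimated at 100000 nM (range 30000 nM to 300000 nM), most likely again reported only as a limit.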

Compound 4, concentration lethal to 50% of the cells: 87100 nM
The estimate for compound 4 lay 1.1-fold (0.06 log units) above the measured number, within the range that was stated.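

In this assay, amino in place of chloro on an aromatic carbon between two ring nitrogen atoms gives the series its first actual number, and the step reads as an at least 1.1-fold lower number from compound 1 to compound 4 (0.05 log units; that floor lies within the scatter). This position therefore tolerates the change, but the true size of the step stays open because compound 1 carries only a limit: the limit of > 100000 nM in this assay, at which 3 of the 4 values shown sit.

Going by these compounds, whether amino at this place gives any step beyond the scatter remains open. So does what a methylamino group, a hydroxyl or a morpholine ring would give there.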